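The source may hold more compounds than are shown below. What is called first, only, known or untested is meant among the compounds shown, and "the series" means these compounds.

Measured compounds in the series:
compound 1 `Cc1n[nH]cc1-c1cccc2c1CCC2c1ncc[nH]1` — 91%
compound 2 `c1cncc(-c2cccc3c2CCC3c2ncc[nH]2)c1` — 36%
compound 3 `CNC(=O)c1cccc2c1CCC2c1ncc[nH]1` — 59%

In a functional assay on CHO cells for agonist activity at Alpha-1A adrenergic receptor (Homo sapiens), read by FLIPR and calcium flux (a lower number here means a smaller maximal response, a higher number a larger maximal response), compound 1 stands highest of the three measured numbers; its nearest neighbour is compound 3, and compound 2 lies furthest below it. Both measured departures from the 3-methyl-1H-pyrazol-4-yl of compound 1 lowered the maximal response: the step to the pyridin-3-yl analogue gave a number 55 percentage points lower from compound 1 to compound 2 (beyond the scatter), the step to the methylcarbamoyl analogue gave a number 32 percentage points lower from compound 1 to compound 3 (beyond the scatter), and between those two the step was a number 23 percentage points higher from compound 2 to compound 3 (beyond the scatter).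

Compound 4 `c1cc(-c2nccs2)c2c(c1)C(c1ncc[nH]1)CC2` is the next untested member; relative to compound 1 the change is 1,3-thiazol-2-yl in place of 3-methyl-1H-pyrazol-4-yl on an aromatic carbon. The two steps that bear on it are those from compound 1 to compound 2 and from compound 1 to compound 3, since each swaps the same group on the same aromatic carbon. Each was a large fall, and the aromatic replacement fell further than the methylcarbamoyl one. The expected step for compound 4 is therefore a large fall, a number 46 percentage points lower from compound 1 to compound 4 (beyond the scatter), in the same direction as those two steps. Compound 4 is accordingly estimated at 45%, within a range of 25% to 70%.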

Compound 4, largest response reached (Emax), in percent of the reference or control that the assay uses: 64%
Compound 4: middle estimate off by 19 percentage points, on the low side; low and high end bracket the measured number.
By their numbers in this assay, from the lowest: compound 2; then compounds 3 and 4 (each within the scatter of the next); then compound 1.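

In this assay, the change from 3-methyl-1H-pyrazol-4-yl to 1,3-thiazol-2-yl gives a number 27 percentage points lower from compound 1 to compound 4 (beyond the scatter) even though a five-membered aromatic ring with 2 hetero atoms stays on the same aromatic carbon, so keeping that ring type does not retain the full response of compound 1. The identity of the aromatic group matters at this position, with a number 28 percentage points higher from compound 2 to compound 4 (beyond the scatter) separating two aromatic replacements, while a number 5 percentage points higher from compound 3 to compound 4 (within the scatter) shows that the aromatic 1,3-thiazol-2-yl and the non-aromatic methylcarbamoyl are not separated here. Nothing available explains why these groups differ in maximal response.

The compounds shown leave open whether the high response of compound 1 depends on the methyl group, on the ring hydrogen-bond donor, or on both, a question that an unsubstituted 1H-pyrazol-4-yl and a pyrazole methylated on nitrogen could help separate. They also leave open how the response changes with a charged group on this aromatic carbon, such as an aminomethyl group or a carboxylic acid.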